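A few compounds are considered here, and "the series" means these few. Any claim that something is new, unique, unknown or untested is made for them only; others in the source may bear on it.

Compound 3 `COc1cc(-c2nnc(SCc3ccccc3)o2)ccc1O` gives the lowest number of the three measured in a functional assay on cells (T-cell, Mus musculus, strain BALB/c) for inhibition, read by MTT assay, with stated times of 24 h and 72 h (a higher number here means a weaker inhibitor, a lower number a stronger inhibitor), at 1250 nM. Compound 2 `COc1cc(-c2nnc(SCc3ccccc3C)o2)ccc1O` gives 8420 nM, and compound 1 `COc1cc(-c2nnc(SCc3cccc(Br)c3)o2)ccc1O` gives 48100 nM. The step of a 6.7-fold lower number from compound 2 to compound 3 (0.83 log units; beyond the scatter) follows hydrogen in place of methyl on an aromatic carbon, and the step of a 38-fold lower number from compound 1 to compound 3 (1.59 log units; beyond the scatter) follows hydrogen in place of bromo on an aromatic carbon. Compound 4 `COc1cc(-c2nnc(SCc3ccc(Br)cc3)o2)ccc1O` differs from compound 3 by bromo in place of hydrogen on an aromatic carbon, placed para to a large group. Of the measured steps, a 38-fold lower number from compound 1 to compound 3 (1.59 log units; beyond the scatter) bears most directly: it also concerns a bromo on that ring, though at a different place, and a 6.7-fold lower number from compound 2 to compound 3 (0.83 log units; beyond the scatter) likewise shows a group added to that ring raising the number. Compound 4 is therefore expected to give a higher number, a 12-fold higher number from compound 3 to compound 4 (1.08 log units; beyond the scatter), with an estimate of 15000 nM and a range from 4000 nM to 60000 nM.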

Compound 4, half-maximal inhibitory concentration: 8830 nM
Estimate against measurement, compound 4: 1.7-fold (0.23 log units) above; the range from low to high includes it.
By their numbers in this assay, from the lowest: compound 3; then compounds 2 and 4 (each within the scatter of the next); then compound 1.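

In this assay, bromo placed para to a large group also raises the number, with a 7.1-fold higher number from compound 3 to compound 4 (0.85 log units; beyond the scatter) as the step, so a bromo at this second place on the ring gives a raised number too. The place of the bromo counts: 4-bromophenyl in place of 3-bromophenyl gives a 5.4-fold lower number from compound 1 to compound 4 (0.74 log units; beyond the scatter) and so recovers part of the loss, while 4-bromophenyl in place of 2-methylphenyl gives a 1.0-fold higher number from compound 2 to compound 4 (0.02 log units; within the scatter) and separates nothing. Nothing available explains these differences. On these data alone, whether a smaller halogen such as fluoro, or an amine or a carboxylic acid, at this place would also raise the number remains open.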